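Chloro to hydroxy on the aromatic ring of compound 1

The compounds below may be only part of what the source reports. "The series", "measured", "known", "first", "only" and "open" are said of these compounds alone.

Measured compounds:
compound 1, `O=C1CSC(c2ccc(Cl)cc2)N1CCN1CCCCC1`, 11%
compound 2, `O=C1CSC(c2c(Cl)cccc2Cl)N1CCN1CCCCC1`, 7%
compound 3, `O=C1CSC(c2ccccc2[N+](=O)[O-])N1CCN1CCCCC1`, 30%

In an ADME assay on Vero cells (Chlorocebus sabaeus) for cytotoxicity, read by neutral red uptake, tested at 3150 ug/mL (on this read-out lower numbers stand for a stronger effect and higher numbers for a weaker effect at the one concentration tested), compound 1 gives 11%, the second highest of the three numbers. Compound 2, with 7%, lies within the scatter of compound 1, so the two cannot be told apart. Compound 3, with 30%, stands beyond the scatter above compound 1.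

Compound 4, `O=C1CSC(c2ccc(O)cc2)N1CCN1CCCCC1`, has not been measured in this assay. It differs from compound 1 in one place: hydroxy in place of chloro on an aromatic carbon. Within the data shown here, no measured pair shows this change, so its effect is not known from these data.

The account expects a modest rise for compound 4, in the direction of a weaker effect, a step of a number 11 percentage points higher from compound 1 to compound 4 (beyond the scatter) that is likely to reach beyond the scatter but not far. From the compounds shown here alone, compound 4 is estimated at 22%, within a range from 6% to 45%, the width reflecting that the change is untested here.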

Compound 4, a percentage reported as activity, at one concentration (the size of the read-out at that concentration, not a potency): 10%
For compound 4 the middle estimate is 12 percentage points above the measured one, within the range that was stated.
By their numbers in this assay, from the lowest: compounds 2, 4 and 1 (each within the scatter of the next); then compound 3.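

In this assay, hydroxy in place of chloro at this position gives a result of a number 1 percentage points lower from compound 1 to compound 4 (within the scatter), so the two compounds cannot be told apart. Among these compounds, this is the first pair here that differs in one place only, and it shows that on an aromatic carbon para to a large group, this exchange, which brings in a hydrogen-bond donor and a hydrogen-bond acceptor, produces no step that can be resolved in this read-out. No available evidence bears on why the two compounds read alike.

The compounds shown leave open how other groups at this position, such as an amine, a carboxylic acid or a methoxy group, would read. They also leave open whether this exchange would give the same result on a compound with a longer chain attached to the shared core.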